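The source may report more compounds than this note shows. Statements on the series, on what has been measured and on what is new or still open speak of the compounds shown alone.

Measured in a functional assay on MDA-MB-231 cells (Homo sapiens) for cytotoxicity, read by sulforhodamine B assay, with a stated time of 72 h; on this read-out lower numbers stand for stronger inhibition of growth and higher numbers for weaker inhibition of growth:
compound 1 `CC(=O)N1c2ccccc2CCC1C(=O)Nc1cc(C(F)(F)F)cc(C(F)(F)F)c1`: > 70000 nM
compound 2 `CCCCCCCCC(=O)N1c2ccccc2CCC1C(=O)Nc1ccccc1C(F)(F)F`: 3350 nM

Compound 1 stands only at a limit, > 70000 nM, and not at a true number. Compound 3 `O=C(Nc1cc(C(F)(F)F)cc(C(F)(F)F)c1)C1CCc2ccccc2N1C(=O)c1ccccc1` keeps the core of compound 1 and carries one change, phenyl in place of methyl on a carbonyl carbon, so acetyl to benzoyl. Within the data shown here, no measured step shows what this change does. Compound 2 reaches 3350 nM with a larger group on that carbonyl carbon, though it differs elsewhere too, so a modest gain in this assay is expected. Staying at the limit of compound 1 remains quite possible for compound 3. The expected step is an at least 2.3-fold lower number from compound 1 to compound 3 (0.36 log units; beyond the scatter). For compound 3 the estimate is 30000 nM, with an expected range of 7000 nM to 90000 nM.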

Compound 3, concentration for 50% growth inhibition: 2430 nM
Estimate against measurement, compound 3: 12-fold (1.09 log units) above, and the stated range ends above it.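

In this assay the swap of methyl for phenyl on this carbonyl carbon, with nothing else changed, gives an at least 28-fold lower number from compound 1 to compound 3 (1.45 log units; beyond the scatter) as a clear gain. This shows that the group on this carbonyl carbon strongly affects growth inhibition, which compound 1 and compound 2 could not show, as they differ in more than one place. Compound 1 is only a limit, so the true size of the step stays unknown: the limit of > 70000 nM in this assay, at which 1 of the 3 values shown sits.

From the compounds shown here alone, whether the gain needs an aromatic ring remains open, as a cyclohexyl group here would test. So does the effect of an amine or a carboxylic acid on the new phenyl.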